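A few compounds are considered here, and "the series" means these few. Any claim that something is new, unique, unknown or untested is made for them only; others in the source may bear on it.

Compound 3, whose structure is `COc1cc(N2C(N)=C(C#N)C(c3ccc(C)o3)C3=C2CC(C)(C)CC3=O)cc(OC)c1OC`, stands highest among the three compounds measured in a functional assay on Ehrlich cells (Mus musculus) for cytotoxicity, tested at 50 ug/mL; a lower number here means a weaker effect, a higher number a stronger effect of the compound at the concentration tested: there compound 3 gives 41%. The two others sit lower. Compound 1, with the structure `COc1ccc(C2C(C#N)=C(N)N(c3cc(OC)c(OC)c(OC)c3)C3=C2C(=O)CC(C)(C)C3)cc1`, gives 11% in this assay, and compound 2, with the structure `COc1cc(N2C(N)=C(C#N)C(c3ccccc3Cl)C3=C2CC(C)(C)CC3=O)cc(OC)c1OC`, gives 20%. Both differences from compound 3 lie beyond the usual scatter.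

Compound 4, with the structure `COc1cc(N2C(N)=C(C#N)C(c3ccc(O)cc3)C3=C2CC(C)(C)CC3=O)cc(OC)c1OC`, has not yet been measured. It differs from compound 3 in one place: 4-hydroxyphenyl in place of 5-methylfuran-2-yl on a saturated ring carbon.

Among the compounds with values here, two measured steps bear on this change. Replacing a 4-methoxyphenyl by the 5-methylfuran-2-yl gave a number 30 percentage points higher from compound 1 to compound 3 (beyond the scatter), and replacing a 2-chlorophenyl by the same five-membered ring gave a number 21 percentage points higher from compound 2 to compound 3 (beyond the scatter). Both times the furan-bearing compound was the higher one. Returning to a six-membered ring of carbon only is therefore expected to lower the read-out, most plausibly toward the number of compound 1, since a 4-hydroxyphenyl resembles a 4-methoxyphenyl closely. The expected step is a number 26 percentage points lower from compound 3 to compound 4 (beyond the scatter). Compound 4 is estimated at 15%, with a range from 4% to 35%.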

Compound 4, a percentage reported as activity, at one concentration (the size of the read-out at that concentration, not a potency): 90%
The estimate for compound 4 lay 75 percentage points below the measured number; measured number outside the range, above it.
By their numbers in this assay, from the lowest: compounds 1 and 2 (each within the scatter of the next); then compound 3; then compound 4.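

Within the data shown here, on the saturated ring carbon, the earlier compounds pointed to the five-membered furan as the better group, yet in this assay 4-hydroxyphenyl in place of 5-methylfuran-2-yl gives a number 49 percentage points higher from compound 3 to compound 4 (beyond the scatter) and in place of 2-chlorophenyl gives a number 70 percentage points higher from compound 2 to compound 4 (beyond the scatter) as the outcome. The closest comparison is hydrogen in place of methyl on the aromatic ring's oxygen, which gives a number 79 percentage points higher from compound 1 to compound 4 (beyond the scatter) from that one small edit, so a six-membered ring of carbon only does not by itself keep the number low. The 4-hydroxyphenyl group carries a hydrogen-bond donor that 5-methylfuran-2-yl lacks, but no measurement shown here explains the rise.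

Going by these compounds, whether the hydroxyl itself is what counts remains open. An amine or a carboxylic acid in its place on the phenyl ring would test this, and the same applies to a hydroxyl on the furan-bearing compound's ring.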